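This account rests on a few compounds, and the source may have more. Where it says the series, first, only, none or still open, it means among the compounds named here.

In a physicochemical assay for lipophilicity, read by HPLC, at pH 7.5 (a lower number here means a more polar compound, a higher number a more lipophilic compound), compound 1 `CC[C@@H](Nc1c(C#N)c(-c2ccc(-c3cccc(C)c3)cc2)nc2cnccc12)C(N)=O` gives 3, compound 2 `CC[C@@H](Nc1c(C#N)c(-c2ccc(-c3ccncc3C)cc2)nc2cnccc12)C(N)=O` gives 2 and compound 3 `CC[C@@H](Nc1c(C#N)c(-c2ccc(-c3ccccc3COC)cc2)nc2cnccc12)C(N)=O` gives 2.6, which places compound 3 second highest of the three. Compound 4 `CC[C@@H](Nc1c(C#N)c(-c2ccc(-c3cccnc3C)cc2)nc2cnccc12)C(N)=O` carries 2-methylpyridin-3-yl in place of 2-(methoxymethyl)phenyl on an aromatic carbon, para to a large group: 2-methylpyridin-3-yl in place of 2-(methoxymethyl)phenyl on an aromatic carbon. Within the data shown here, no measured compound holds this exact group. Compound 2, with 3-methylpyridin-4-yl, is the nearest measured comparison. Two modest steps bear on the change: a number 0.60 log units higher from compound 2 to compound 3 (beyond the scatter), read in reverse, and a number 1.00 log units lower from compound 1 to compound 2 (beyond the scatter), where 3-methylpyridin-4-yl enters. A modest fall in this assay is therefore expected, with an estimated step of a number 0.50 log units lower from compound 3 to compound 4 (beyond the scatter). For compound 4 the estimate is 2.1, with an expected range of 1.7 to 2.5.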

Compound 4, distribution coefficient: 1.9
The estimate for compound 4 lay 0.20 log units above the measured number; the measured number falls inside the stated range.
By their numbers in this assay, from the lowest: compounds 4 and 2 (each within the scatter of the next); then compound 3; then compound 1.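

In this assay, the two methylpyridine groups are not told apart at this place, para to a large group: a number 0.10 log units lower from compound 2 to compound 4 (within the scatter) is the step between them. Among these four compounds, both lie under the two carbon-only aryl groups, with a number 0.70 log units lower from compound 3 to compound 4 (beyond the scatter) and a number 1.10 log units lower from compound 1 to compound 4 (beyond the scatter) as the steps for 2-methylpyridin-3-yl, so this pattern now holds for a second placing of the ring nitrogen. Nothing available gives a reason for these steps. As far as these compounds go, how an amine or a carboxylic acid on this ring would read remains open, as does a longer chain in place of the methyl.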